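Amide-linked aryloxyacetyl series: methoxy to methyl swap

The source may hold more compounds than are shown below. What is called first, only, known or untested is meant among the compounds shown, and "the series" means these compounds.

Measured compounds:
compound 1 `O=C(COc1ccc(Cl)cc1)N1CCN(c2ncnc3sc(F)cc23)CC1` — 6350 nM
compound 2 `Nc1nc(N2CCN(C(=O)CCc3ccccc3)CC2)c2cc(F)sc2n1` — 6990 nM
compound 3 `COc1ccc(OCC(=O)N2CCN(c3nc(N)nc4sccc34)CC2)cc1` — 72 nM

Among the measured compounds shown here, in a functional assay on cells (Lymphocyte) (on this read-out lower numbers stand for stronger inhibition and higher numbers for weaker inhibition), compound 3 gives 72 nM, the lowest number of the three, and its distance from compound 1 and from compound 2 lies well beyond the scatter in both cases, so compound 3 is the most potent compound measured so far. Compound 1 and compound 2 sit close to each other, within the scatter.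

The next compound, compound 4 `Cc1cccc(OCC(=O)N2CCN(c3nc(N)nc4sccc34)CC2)c1`, keeps the shared core of compound 3 and alters only the outer aryl group: 3-methylphenyl in place of 4-methoxyphenyl on an oxygen on a saturated carbon. For the measured compounds named here, no pair of measured compounds differs in one place, so the size of this kind of step has no precedent here. The change removes the single hydrogen-bond acceptor of the leaving group and moves the substituent on the ring; a modest shift, most likely toward a higher number, is expected rather than a large one.

For compound 4 the expected step from compound 3 is a 2.1-fold higher number from compound 3 to compound 4 (0.32 log units; beyond the scatter). Compound 4 is estimated at 150 nM, within a range from 40 nM to 600 nM.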

Compound 4, half-maximal inhibitory concentration: 210 nM
Compound 4: the middle estimate sits 1.4-fold (0.15 log units) below what was measured; measured number inside the range.
By their numbers in this assay, from the lowest: compound 3; then compound 4; then compounds 1 and 2 (each within the scatter of the next).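

In this assay, among the compounds shown here, this is the first single-place step: 3-methylphenyl in place of 4-methoxyphenyl on an oxygen on a saturated carbon gives a 2.9-fold higher number from compound 3 to compound 4 (0.46 log units; beyond the scatter), so this position accepts the change at a modest cost. The step combines the loss of the hydrogen-bond acceptor of the leaving group with a moved ring substituent, and the share of each in the step cannot be separated. No measurement here bears on the reason for the step.

Open, going by these compounds, is whether 4-methylphenyl or 3-methoxyphenyl would split the change of substituent from the change of its place, and whether an amine, a carboxylic acid or a longer chain on the ring would hold the number of compound 3. Compound 1 and compound 2 differ from compound 3 in more than one place and add nothing on this position.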